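A Swap on the Ring Nitrogen of Compound 1

The compounds below may be only part of what the source reports. "The series", "measured", "known", "first", "only" and "open" are said of these compounds alone.

Measured compounds:
Compound 1 `COc1cccc(N2C(=O)COc3ccc(-c4cccc(NS(=O)(=O)c5ccc(F)cc5)c4)cc32)c1`: > 40000 nM
Compound 2 `O=C1COc2ccc(-c3cnc4ccccc4c3)cc2N1C1CCCCC1`: > 40000 nM
Compound 3 `COc1ccc(N2C(=O)COc3ccc(-c4cnc5ccccc5c4)cc32)cc1`: > 40000 nM

In a functional assay on A-375 cells (Homo sapiens) for antiproliferative activity, read by MTT assay, with a stated time of 72 h (on this read-out higher numbers stand for weaker inhibition and lower numbers for stronger inhibition), compound 1 gives > 40000 nM, which is a limit and not a number. It therefore has no rank against the other two compounds, whose values are limits as well: the limit of > 40000 nM in this assay, at which 3 of the 3 values shown sit.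

Compound 4 `Cc1ccc(N2C(=O)COc3ccc(-c4cccc(NS(=O)(=O)c5ccc(F)cc5)c4)cc32)cc1` keeps the core of compound 1 and changes one group: 4-methylphenyl in place of 3-methoxyphenyl on an amide-type nitrogen in a ring. Within the data shown here, only one measured step touches this place, a step that the two limits leave unreadable from compound 2 to compound 3, and its size cannot be read. That step also involves neither 3-methoxyphenyl nor 4-methylphenyl, so the measurements give no size to carry over.

With nothing to suggest otherwise, no step beyond the scatter is expected, in either direction. The expected size, which is only an estimate, is a number no higher from compound 1 to compound 4 (the limit leaves the size open). A limit is the most likely report for the new compound. For compound 4 the estimated value is 40000 nM, with an expected range from 12000 nM to 80000 nM.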

Compound 4, half-maximal inhibitory concentration: 36200 nM
Estimate against measurement, compound 4: 1.1-fold (0.04 log units) above, within the range that was stated.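

In this assay, among these compounds, compound 4 gives 36200 nM, the first value in this set that is a number and not a limit. Placing 4-methylphenyl in place of 3-methoxyphenyl on the amide-type nitrogen in a ring gives an at least 1.1-fold lower number from compound 1 to compound 4 (0.04 log units; that floor lies within the scatter), so the true size of this change remains open. The step from compound 2 to compound 3 still cannot be read, and most of the set stays at a limit: the limit of > 40000 nM in this assay, at which 3 of the 4 values shown sit.

Going by these compounds, whether an amine or a carboxylic acid on the phenyl ring at this nitrogen, or a plain methyl on the nitrogen itself, would shift the number beyond the scatter stays open. Also open is how far 4-methylphenyl would carry over to the other compounds shown.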